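Aryl substituent swap on the anilide arm: methyl to methoxy

The compounds below may be only part of what the source reports. "The series", "measured", "known", "first", "only" and "open" are said of these compounds alone.

Compound 3 `Cc1cc(C(C)C(=O)NCc2ccc(C(F)(F)F)nc2N2CCC(C)CC2)ccc1NS(C)(=O)=O` gives 0.6 nM in an assay on cells for antagonist activity at transient receptor potential cation channel subfamily V member 1 (Homo sapiens), read by FLIPR and calcium flux, with a stated time of 15 min (a higher number here means a weaker inhibitor, a lower number a stronger inhibitor), and stands lowest of the three numbers in hand. Compound 1 `CC1CCN(c2nc(C(F)(F)F)ccc2CNC(=O)C(C)c2ccc(NS(C)(=O)=O)c(Cl)c2)CC1` gives 2.3 nM and compound 2 `CC1CCN(c2nc(C(F)(F)F)ccc2CNC(=O)C(C)c2ccc(NS(C)(=O)=O)c(Br)c2)CC1` gives 3.2 nM; the steps of a 3.8-fold lower number from compound 1 to compound 3 (0.58 log units; beyond the scatter) and a 5.3-fold lower number from compound 2 to compound 3 (0.73 log units; beyond the scatter) both lie beyond the scatter, while a 1.4-fold higher number from compound 1 to compound 2 (0.14 log units; within the scatter) does not. Compound 4 `COc1cc(C(C)C(=O)NCc2ccc(C(F)(F)F)nc2N2CCC(C)CC2)ccc1NS(C)(=O)=O` carries methoxy in place of methyl on an aromatic carbon. Among the compounds with values here, no measured step exchanges methyl for methoxy; the two steps that reach compound 3 replace a halogen by methyl, and show only that the methyl compound sits below both halogen compounds. The expected step of a 2.0-fold higher number from compound 3 to compound 4 (0.30 log units; within the scatter) is therefore set small, leaning toward a higher number. Compound 4 is estimated at 1.2 nM, with a range of 0.4 nM to 4 nM.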

Compound 4, inhibition constant: 0.8 nM
The estimate for compound 4 lay 1.5-fold (0.18 log units) above the measured number; the range from low to high includes it.
By their numbers in this assay, from the lowest: compounds 3 and 4 (each within the scatter of the next); then compounds 1 and 2 (each within the scatter of the next).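

In this assay, the position ortho to a methanesulfonamido group takes methoxy as well as methyl, with its added hydrogen-bond acceptor, giving a 1.3-fold higher number from compound 3 to compound 4 (0.12 log units; within the scatter). The gap to the halogens also holds for methoxy, with a 4.0-fold lower number from compound 2 to compound 4 (0.60 log units; beyond the scatter) and a 2.9-fold lower number from compound 1 to compound 4 (0.46 log units; beyond the scatter), so it is not peculiar to methyl. No measurement in hand accounts for these gaps.

Open, as far as these compounds go, is whether a hydroxyl, an ethoxy or a dimethylamino group at this position would fall with methyl and methoxy or with chloro and bromo.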